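Fluoro in Place of Chloro: Expected Cytotoxicity of Compound 3

This account rests on a few compounds, and the source may have more. Where it says the series, first, only, none or still open, it means among the compounds named here.

Compound 1 `NS(=O)(=O)c1ccc(N2N=C(c3ccc(Cl)cc3Cl)CC2c2cn(-c3ccccc3)nc2-c2ccccc2)cc1`: in an ADME assay on Vero cells (Chlorocebus sabaeus) for cytotoxicity, read by MTT assay, with a stated time of 72 h (on this read-out lower numbers stand for higher toxicity in this test and higher numbers for lower toxicity in this test), compound 1 gives > 437000 nM
Compound 2 `NS(=O)(=O)c1ccc(N2N=C(c3ccc(Cl)cc3)CC2c2cn(-c3ccccc3)nc2-c2ccccc2)cc1`: in this assay compound 2 gives > 206000 nM

Both values shown are limits of the assay and not numbers. For compound 2 the result is a limit only, as the limit of > 206000 nM in this assay, at which 1 of the 2 values shown sits, records. For compound 1 the result is likewise a limit, as the limit of > 437000 nM in this assay, at which 1 of the 2 values shown sits, records. Within the data shown here, the single measured step, a step that the two limits leave unreadable from compound 1 to compound 2, a hydrogen in place of a chloro on an aromatic carbon, therefore cannot be sized, and it carries no readable information.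

Compound 3 `NS(=O)(=O)c1ccc(N2N=C(c3ccc(F)cc3)CC2c2cn(-c3ccccc3)nc2-c2ccccc2)cc1` differs from compound 2 by fluoro in place of chloro on an aromatic carbon. Among the measured compounds shown here, no measured step bears on this change with a readable size; the only guidance is that compound 2 sits at a limit in this assay. Compound 3 is therefore expected to show no step beyond the scatter, a step that the limit leaves unreadable from compound 2 to compound 3, and most probably to be reported again as a limit. The estimate for compound 3 in this assay is 300000 nM, with a range from 100000 nM to 1000000 nM.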

Compound 3, half-maximal cytotoxic concentration: > 807000 nM
Compound 3: a limit, no number (the forecaster's own chance of this, stated with the estimate: 80%); middle value at least 2.6-fold (0.42 log units) away from the limit.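

In this assay compound 1, compound 2 and compound 3 are all recorded as limits and not numbers, and the steps among them cannot be read. The compounds shown leave open whether exchanging chloro for fluoro or hydrogen changes cytotoxicity at all.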